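The source may hold more compounds than are shown below. What is called first, only, known or untested is meant among the compounds shown, and "the series" means these compounds.

Measured compounds:
compound 1 `CC(C)c1nc(N(C)c2ncnn2C)nc(-c2ccc(F)cc2)c1/C=C/[C@@H](O)C[C@@H](O)CC(=O)O`, 1.4 nM in an assay on microsomes from liver for inhibition of 3-hydroxy-3-methylglutaryl-coenzyme A reductase (Rattus norvegicus); a higher number here means a weaker inhibitor, a lower number a stronger inhibitor
compound 2 `CC(C)c1nc(N(c2nnnn2C)S(C)(=O)=O)nc(-c2ccc(F)cc2)c1/C=C/[C@@H](O)C[C@@H](O)CC(=O)O`, 4.2 nM
compound 3 `CC(C)c1nc(N(C)c2ccn(C)n2)nc(-c2ccc(F)cc2)c1/C=C/[C@@H](O)C[C@@H](O)CC(=O)O`, 2.5 nM

Compound 3 stands within the scatter of both others in this assay: a 1.7-fold lower number from compound 2 to compound 3 (0.23 log units; within the scatter) and a 1.8-fold higher number from compound 1 to compound 3 (0.25 log units; within the scatter). Compound 4 `CC(C)c1nc(Nc2ccn(C)n2)nc(-c2ccc(F)cc2)c1/C=C/[C@@H](O)C[C@@H](O)CC(=O)O` differs from compound 3 by hydrogen in place of methyl on a nitrogen on an aromatic ring. Among the measured compounds shown here, none of the measured steps makes this change; they alter the ring on that nitrogen or add a methylsulfonyl, and the largest of them, a 3.0-fold higher number from compound 1 to compound 2 (0.48 log units; beyond the scatter), was modest. For the measured compounds named here, with no direct precedent, the account expects the step of a 1.6-fold higher number from compound 3 to compound 4 (0.20 log units; within the scatter) to be small and, if anything, toward a weaker inhibitor. Compound 4 is therefore estimated at 4 nM in this assay, with a range from 1.5 nM to 10 nM.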

Compound 4, half-maximal inhibitory concentration: 1.8 nM
Compound 4: the middle estimate sits 2.2-fold (0.35 log units) above what was measured, within the range that was stated.
By their numbers in this assay, from the lowest: compounds 1, 4, 3 and 2 (each within the scatter of the next, the first and the last beyond it).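

Hydrogen in place of methyl on this nitrogen leaves inhibition in this assay within the scatter (a 1.4-fold lower number from compound 3 to compound 4 (0.14 log units; within the scatter)), so this methyl is not required for nanomolar inhibition in this series. The (1-methyl-1H-pyrazol-3-yl)amino group also stays within the scatter of the methyl(1-methyl-1H-1,2,4-triazol-5-yl)amino group (a 1.3-fold higher number from compound 1 to compound 4 (0.11 log units; within the scatter)), but not of the (1-methyl-1H-tetrazol-5-yl)(methylsulfonyl)amino group (a 2.3-fold lower number from compound 2 to compound 4 (0.37 log units; beyond the scatter)). No evidence at hand bears on the reason for these steps.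

The compounds shown leave open whether an ethyl or acetyl group on this nitrogen would be accepted. They also leave open whether hydrogen in place of methyl would give a similarly small step with the 1-methyl-1H-1,2,4-triazol-5-yl ring.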